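The compounds below may be only part of what the source reports. "The series", "measured", "known", "first", "only" and "open" are said of these compounds alone.

Series notes. In a functional assay on HT-29 cells (Homo sapiens) for cytotoxicity, read by MTT assay, with a stated time of 72 h (on this read-out lower numbers stand for stronger inhibition and higher numbers for weaker inhibition), compound 1 `Cc1ccccc1NC(=O)CN1CCN(c2nnc(Cc3ccccc3)c3ccccc23)CC1` gives 113000 nM, and compound 2 `O=C(CN1CCN(c2nnc(Cc3ccncc3)c3ccccc23)CC1)Nc1cc(C(F)(F)F)ccc1Cl` gives 4810 nM; compound 2 holds the lowest of the two numbers, with compound 1 standing clearly higher, a gap beyond the usual scatter. Compound 3 `O=C(CN1CCN(c2nnc(Cc3ccccc3)c3ccccc23)CC1)Nc1cc(C(F)(F)F)ccc1Cl` is not yet measured. The change from compound 2 to compound 3 is phenyl in place of pyridin-4-yl on a saturated chain carbon bound to an aromatic carbon. Going by the values given here, compounds 1 and 2 differ in two places, so no single step isolates this change. For compound 3 a modest step toward a higher number in this assay is expected, a 1.7-fold higher number from compound 2 to compound 3 (0.22 log units; within the scatter). For compound 3 the estimate is 8000 nM, with a range from 2500 nM to 30000 nM.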

Compound 3, half-maximal inhibitory concentration: 66800 nM
Estimate against measurement, compound 3: 8.4-fold (0.92 log units) below, outside the stated range (above it).
By their numbers in this assay, from the lowest: compound 2; then compounds 3 and 1 (each within the scatter of the next).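

In this assay phenyl in place of pyridin-4-yl on a saturated chain carbon bound to an aromatic carbon gives a 14-fold higher number from compound 2 to compound 3 (1.14 log units; beyond the scatter) and shows this position to be sensitive to the change. With benzyl kept, 2-chloro-5-(trifluoromethyl)phenyl in place of 2-methylphenyl on an amide-type nitrogen gives a 1.7-fold lower number from compound 1 to compound 3 (0.23 log units; within the scatter) and does not separate the pair, so among these compounds the low number of compound 2 goes with pyridin-4-yl. Nothing measured here explains the size of this step.

The compounds shown leave open how pyridin-2-yl or pyridin-3-yl would read at this carbon. They also leave open whether 2-methylphenyl on the amide-type nitrogen would read the same with pyridin-4-yl in place.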